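A few compounds are considered here, and "the series" means these few. Any claim that something is new, unique, unknown or untested is made for them only; others in the source may bear on it.

Compound 3 `Cc1ccc2c(c1C)NC(=O)C2(c1ccc(O)cc1)C1CCCCCC1` reaches only a limit in a functional assay on PC-3 cells (Homo sapiens) for cytotoxicity, read by WST assay, with a stated time of 72 h (a higher number here means a weaker inhibitor, a lower number a stronger inhibitor), where compound 3 gives > 1000 nM. Compound 2 `Cc1cccc2c1NC(=O)C2(c1ccc(O)cc1)C1CCCCCC1` also reports a limit in this assay, with compound 2 at > 1000 nM. The step that the two limits leave unreadable from compound 2 to compound 3 is therefore unreadable, both values resting at the limit of > 1000 nM in this assay, at which 2 of the 3 values shown sit. Compound 1 `O=C1Nc2c(ccc(F)c2F)C1(c1ccc(O)cc1)C1CCCCCC1` stands apart, giving 12 nM in this assay. Compound 4 `Cc1c(F)ccc2c1NC(=O)C2(c1ccc(O)cc1)C1CCCCCC1` arises from compound 3 by fluoro in place of methyl on an aromatic carbon. The methyl that compound 2 and compound 3 share remains in compound 4, and compound 2 already sits at its limit, so no return toward the potency of compound 1 is expected. The step that the limit leaves unreadable from compound 3 to compound 4 is expected to stay hidden against the limit. For compound 4 in this assay the estimate is 3000 nM, within 800 nM to 20000 nM.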

Compound 4, half-maximal inhibitory concentration: 30 nM
Beside the measured number, compound 4's estimate is 100-fold (2.00 log units) above it; the measured number lies below the stated range.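

In this assay, fluoro on this aromatic carbon, ortho to a methyl group, gives an at least 33-fold lower number from compound 3 to compound 4 (1.52 log units; beyond the scatter), and in place of hydrogen on the same carbon it gives an at least 33-fold lower number from compound 2 to compound 4 (1.52 log units; beyond the scatter). The remaining difference from the difluoro core is much smaller, with a 2.5-fold higher number from compound 1 to compound 4 (0.40 log units; beyond the scatter). The methyl shared by compound 2, compound 3 and compound 4 therefore does not by itself hold a compound at the limit.

From the compounds shown here alone, whether this recovery is particular to fluoro stays open, and chloro, methoxy or a nitrile on this carbon would test it. The full size of the first two steps also stays open, since compound 2 and compound 3 give only limits: the limit of > 1000 nM in this assay, at which 2 of the 4 values shown sit.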